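The source may report more compounds than this note shows. Statements on the series, on what has been measured and on what is new or still open speak of the compounds shown alone.

Among the two compounds measured so far, compound 2 `O=C(CN(c1nc(Cl)nc2[nH]cnc12)C1CC1)N[C@@H](CO)C(=O)O` stands higher: in a functional assay on the whole organism (Tail, strain ICR) with Mus musculus as the target, in the tail flick test, with a stated time of 150 min, at a dose of 25 umol/kg by the oral route (a lower number here means a weaker effect, a higher number a stronger effect of the compound at the dose given), compound 2 gives 18.8%, whereas compound 1 `O=C(O)[C@@H]1CCCN1C(=O)CN(c1nc(Cl)nc2[nH]cnc12)C1CC1` gives 7.29% in this assay, the only measured step being a number 11.5 percentage points higher from compound 1 to compound 2 (beyond the scatter). Compound 3 `O=C(O)CC[C@H](NC(=O)CN(c1nc(Cl)nc2[nH]cnc12)C1CC1)C(=O)O` has not yet been measured in this assay. It differs from compound 2 in one place: carboxymethyl in place of hydroxy on a saturated chain carbon, two bonds along the chain from an amide-type nitrogen and a carbonyl carbon. Within the data shown here, no measured step touches this position directly; the step from compound 1 to compound 2 swaps the whole amino acid part rather than the hydroxy group alone, so it bears on the present change only loosely and gives no direction. The step of a number 1.2 percentage points higher from compound 2 to compound 3 (within the scatter) is therefore expected to be small, probably within the scatter, with no direction claimed. Compound 3 is accordingly estimated at 20%, with a range from 5% to 40%.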

Compound 3, a percentage reported as activity, at one dose (the size of the read-out at that dose, not a potency): 29.5%
Compound 3: the middle estimate sits 9.5 percentage points below what was measured; measured number inside the range.
By their numbers in this assay, from the lowest: compound 1; then compound 2; then compound 3.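

Replacing hydroxy with carboxymethyl on this saturated chain carbon, two bonds along the chain from an amide-type nitrogen and a carbonyl carbon, is not a neutral change in this assay: it gives a number 10.7 percentage points higher from compound 2 to compound 3 (beyond the scatter). Among these compounds, this is the first step confined to this position, and it shows that the read-out responds to the side chain alone, with the shared core and the amino acid carboxylic acid unchanged; cut one bond further out, the same change reads hydroxymethyl to 2-carboxyethyl. Nothing available accounts for the size or direction of this step.

From the compounds shown here alone, it remains open whether the step follows from the terminal carboxylic acid or from the longer chain, a question that a plain alkyl chain, a primary amide or an amine at this position could help to separate. Going by these compounds, it is also open whether the step would hold at other doses or times.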